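Carboxy in Place of Chloro on the Aromatic Ring

This account rests on a few compounds, and the source may have more. Where it says the series, first, only, none or still open, it means among the compounds named here.

Of the compounds shown here, three with a shared core have been tested in an assay on HEK293 cells for inhibition of N-acylethanolamine-hydrolyzing acid amidase (Rattus norvegicus), read by LC-MS, with a stated time of 30 min; on this read-out higher numbers stand for weaker inhibition and lower numbers for stronger inhibition. Compound 1 `Cc1ccc(CCCCCC(=O)N2CCOC2=O)cc1C` carries two methyl groups on its aromatic ring. For compound 1 the result is only a limit of the assay, > 20000 nM. Compound 2 `CSc1cccc(CCCCCC(=O)N2CCOC2=O)c1` carries a methylthio group instead, and in this assay compound 2 gives 12800 nM. Compound 3 `O=C(CCCCCc1ccc(Cl)cc1)N1CCOC1=O` carries a chloro group, and in this assay compound 3 gives 4600 nM, the lowest of the two numbers that are not limits; the gap to compound 2 lies beyond the usual scatter, so compound 3 stands as the stronger of that pair. The limit for compound 1 is noted in the limit of > 20000 nM in this assay, at which 1 of the 3 values shown sits.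

Compound 4 `O=C(O)c1ccc(CCCCCC(=O)N2CCOC2=O)cc1` is the next compound. It differs from compound 3 by carboxy in place of chloro on an aromatic carbon. For the measured compounds named here, no measured pair shows what such a change does here; the three measured compounds vary only in small, uncharged substituents. The expectation is a weaker result, a step of a 3.3-fold higher number from compound 3 to compound 4 (0.51 log units; beyond the scatter) beyond the scatter, while the limit for compound 1 shows that a moderate change on this ring can push a value out of range. Compound 4 is estimated at 15000 nM, expected between 5000 nM and 30000 nM.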

Compound 4, half-maximal inhibitory concentration: > 20000 nM
Compound 4: only a limit was reported (the forecaster's own chance of this, stated with the estimate: 35%); at least 1.3-fold (0.12 log units) between middle value and limit.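

Setting carboxy in place of chloro on the aromatic carbon para to a large group gives an at least 4.3-fold higher number from compound 3 to compound 4 (0.63 log units; beyond the scatter) in this assay. For the compounds shown here, this is the first pair here that differs in one place only, so it shows directly that this single position can decide whether a measurable value is obtained, something the earlier compounds, which differ from one another in their ring substituents without any such linked step, could only hint at. Compound 4 gives only a limit of the assay, > 20000 nM, so the step sets a minimum size and the full size of the change stays unknown, and compound 4 now counts among the compounds at that limit: the limit of > 20000 nM in this assay, at which 2 of the 4 values shown sit.

The compounds shown leave open whether the loss belongs to the free carboxy itself or would also appear with its methyl ester, a primary amide or an amine at the same place. They also leave open whether a bromo or fluoro group could stand in for chloro here, and whether a longer chain would alter the effect of carboxy on this ring.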